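The source may report more compounds than this note shows. Statements on the series, on what has been measured and on what is new or still open speak of the compounds shown alone.

Working notes on the series. Going by the values given here, compound 2 `CN(C)CCn1cnnc1-c1cc(Oc2ccc(NC(=O)N/N=C/c3ccc(F)cc3F)cc2F)ccn1` is the lowest of the two numbers so far in a functional assay on U-87MG ATCC cells (Homo sapiens) for cytotoxicity, read by MTT assay, with a stated time of 72 h (a higher number here means a weaker inhibitor, a lower number a stronger inhibitor), where compound 2 gives 1900 nM. Among the compounds with values here, its nearest neighbour is compound 1 `CN(C)CCn1cnnc1-c1cc(Oc2ccc(NC(=O)N/N=C/c3ccc(O)c(Br)c3)cc2F)ccn1`, which in this assay gives 12400 nM; the one measured step, a 6.5-fold lower number from compound 1 to compound 2 (0.81 log units; beyond the scatter), is the only one that bears on the change under consideration. Compound 3 `CN(C)CCn1cnnc1-c1cc(Oc2ccc(NC(=O)N/N=C/c3ccc(O)cc3O)cc2F)ccn1` is not yet measured; it differs from compound 2 by 2,4-dihydroxyphenyl in place of 2,4-difluorophenyl on a carbon with a double bond to nitrogen. Within the data shown here, the only guide runs in the opposite sense: the step to compound 2 lowered the number when a hydroxyl-bearing ring gave way to the 2,4-difluorophenyl, and compound 3 brings two hydroxyls onto that ring in place of the two fluorines. A return to a higher number in this assay is therefore expected, beyond the scatter, though the exact size is uncertain with a single step to go on; the step expected for compound 3 is a 3.7-fold higher number from compound 2 to compound 3 (0.57 log units; beyond the scatter). For compound 3 the estimate is 7000 nM, with a range from 2500 nM to 20000 nM.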

Compound 3, half-maximal inhibitory concentration: 15400 nM
The estimate for compound 3 lay 2.2-fold (0.34 log units) below the measured number; the range from low to high includes it.
By their numbers in this assay, from the lowest: compound 2; then compounds 1 and 3 (each within the scatter of the next).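

Across the carbon with a double bond to nitrogen in this assay, exchanging the two fluorines for two hydroxyls gives an 8.1-fold higher number from compound 2 to compound 3 (0.91 log units; beyond the scatter), so the 2,4-difluorophenyl of compound 2 now holds the lowest number against two different hydroxyl-bearing rings rather than one. The two hydroxyl-bearing rings are not separated, with a 1.2-fold higher number from compound 1 to compound 3 (0.09 log units; within the scatter), so the 2,4-dihydroxyphenyl and the 3-bromo-4-hydroxyphenyl stand level here. The lower number of compound 2 therefore does not depend on which of these two hydroxyl-bearing rings it is set against. Nothing at hand gives a reason for these differences.

From the compounds shown here alone, it remains open whether the lower number follows the fluorines themselves or only the absence of hydroxyls, which an unsubstituted phenyl or a methoxyphenyl at this place would help separate. Going by these compounds, whether a ring bearing an amine or a carboxylic acid would fall with compound 2 or with the hydroxyl-bearing pair is also open.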